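This account rests on a few compounds, and the source may have more. Where it says the series, first, only, none or still open, it means among the compounds named here.

Measured so far:
compound 1, `CC(C)=CCC/C(C)=C/C[C@]12C[C@@H](CC=C(C)C)C(C)(C)[C@](CC=C(C)C)(C(=O)C(C(=O)c3ccc(O)c(O)c3)=C1O)C2=O` — 8.6 ug/mL
compound 2, `CC(C)=CCC/C(C)=C/C[C@@H]1C[C@]2(CC=C(C)C)C(=O)[C@@](CC=C(C)C)(C(=O)C(C(=O)c3ccc(O)c(O)c3)=C2O)C1(C)C` — > 20 ug/mL

In a functional assay on HCT-116 cells (Homo sapiens) for inhibition (a higher number here means a weaker inhibitor, a lower number a stronger inhibitor), compound 1 gives 8.6 ug/mL. For compound 2 the reading in this assay is only a limit, > 20 ug/mL, so its true potency is not known as a number; the compound sits at the limit of > 20 ug/mL in this assay, at which 1 of the 2 values shown sits.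

Compound 3, `CC(C)=CCC/C(C)=C/C[C@@H]1C[C@]2(C/C=C(\C)CCC=C(C)C)C(=O)[C@@](CC=C(C)C)(C(=O)C(C(=O)c3ccc(O)c(O)c3)=C2O)C1(C)C`, has not yet been measured in this assay. It differs from compound 2 by 3-methylbut-2-en-1-yl in place of hydrogen on a saturated chain carbon bound to a double-bonded chain carbon. Because compound 2 is known only as the limit of > 20 ug/mL in this assay, at which 1 of the 2 values shown sits, any step from it can only be judged against that boundary. He expects a step from compound 2 to compound 3 of about a step that the limit leaves unreadable from compound 2 to compound 3, that is, none beyond the scatter, with the result most likely again at the limit. He estimates compound 3 in this assay at 25 ug/mL, with a range from 9 ug/mL to 60 ug/mL.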

Compound 3, half-maximal inhibitory concentration: 4.92 ug/mL
Beside the measured number, compound 3's estimate is 5.1-fold (0.71 log units) above it; the whole stated range lies above it.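

In this assay, replacing hydrogen with 3-methylbut-2-en-1-yl on a saturated chain carbon bound to a double-bonded chain carbon gives an at least 4.0-fold lower number from compound 2 to compound 3 (0.60 log units; beyond the scatter), so this place responds to the change when it starts from compound 2. That step can be given only as a minimum, because compound 2 is known only as a limit: the limit of > 20 ug/mL in this assay, at which 1 of the 3 values shown sits.

The same exchange made from the other side gives a 1.7-fold lower number from compound 1 to compound 3 (0.24 log units; within the scatter), so here the change yields no difference that can be told from the scatter.

The compounds shown leave open whether a chain longer than 3,7-dimethylocta-2,6-dien-1-yl would shift the reading further at this place. They also leave open whether the double bonds of the chain matter, which a saturated chain of the same length or a chain ending in a carboxylic acid or an amine could test.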